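A few compounds are considered here, and "the series" means these few. Any claim that something is new, unique, unknown or untested is made for them only; others in the source may bear on it.

In a functional assay on HCC1954 cells (Homo sapiens) for antiproliferative activity, read by MTT assay, with a stated time of 72 h (on this read-out lower numbers stand for stronger inhibition and higher numbers for weaker inhibition), compound 1 `O=C(Nc1ccccc1C(=O)O/N=C1\CCCc2noc(-c3ccc(F)cc3)c21)c1ccccc1F` reaches only a limit of the assay, not a number, at > 25000 nM. Compound 2 `O=C(Nc1ccccc1C(=O)O/N=C1\CCCc2onc(-c3ccc(F)cc3)c21)c1cccc(F)c1` likewise is reported only as a limit, > 25000 nM. Compound 3 `CC1(C)C/C(=N\OC(=O)c2cccc(NC(=O)c3cccc(F)c3)c2)c2c(-c3ccc(F)cc3)noc2C1` too gives only a limit, > 25000 nM. Compound 3 thus stands together with the other two at the limit of > 25000 nM in this assay, at which 3 of the 3 values shown sit; no measurable number is known for any of the three. Compound 4 `COc1ccc(-c2noc3c2/C(=N/OC(=O)c2cccc(NC(=O)c4cccc(F)c4)c2)CC(C)(C)C3)cc1OC` differs from compound 3 by 3,4-dimethoxyphenyl in place of 4-fluorophenyl on an aromatic carbon. Among the compounds with values here, no measured step between these compounds exists to guide the size of this change, so the step that the limit leaves unreadable from compound 3 to compound 4 is expected to be none beyond the scatter in this assay. Compound 4 is therefore estimated at 40000 nM, between 12000 nM and 120000 nM, and is expected most likely to be reported again only as a limit in this assay.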

Compound 4, half-maximal inhibitory concentration: > 25000 nM
Compound 4: a limit, no number (the forecaster's own chance of this, stated with the estimate: 85%); the middle value is on the limit's open side.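

Within the data shown here, compound 3 and compound 4 are both reported only as limits, so no step between them can be read: the limit of > 25000 nM in this assay, at which 4 of the 4 values shown sit. The compounds shown leave open which change, if any, would give a measurable number in this assay at all.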